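Regioisomeric methylphenyl swap on a triazole: compound 4 expected

A few compounds are considered here, and "the series" means these few. Any claim that something is new, unique, unknown or untested is made for them only; others in the source may bear on it.

In a functional assay on HCT-116 cells (Homo sapiens) for antiproliferative activity, read by MTT assay, with a stated time of 48 h (a lower number here means a stronger inhibitor, a higher number a weaker inhibitor), compound 1 `Cc1ccccc1-n1nncc1CN1C(=O)C2(C(C#N)=C(N)Oc3c2c2nc4ccccc4nc2c2ccccc32)c2ccccc21` gives > 50000 nM, which is a limit of the assay rather than a number. Compound 2 `Cc1cccc(-n2nncc2CN2C(=O)C3(C(C#N)=C(N)Oc4c3c3nc5ccccc5nc3c3ccccc43)c3ccccc32)c1` gives > 50000 nM in this assay, again a limit. The change 3-methylphenyl in place of 2-methylphenyl on an aromatic nitrogen therefore gives a step that the two limits leave unreadable from compound 1 to compound 2. Compound 3 `Cc1ccccc1-n1nncc1CN1C(=O)C2(C(C#N)=C(N)Oc3c(N)cc4nc5ccccc5nc4c32)c2ccccc21` gives > 50000 nM in this assay, also a limit; the difference between the cores of compound 3 and compound 1 is not broken down here. Compound 4 `Cc1cccc(-n2nncc2CN2C(=O)C3(C(C#N)=C(N)Oc4c(N)cc5nc6ccccc6nc5c43)c3ccccc32)c1` is not yet measured; it differs from compound 3 by 3-methylphenyl in place of 2-methylphenyl on an aromatic nitrogen, the same change as from compound 1 to compound 2. Because (the limit of > 50000 nM in this assay, at which 3 of the 3 values shown sit), compound 4 is expected to sit at the limit as well, with an expected step that the limit leaves unreadable from compound 3 to compound 4. Compound 4 is thus estimated at 80000 nM in this assay, most likely reported only as a limit.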

Compound 4, half-maximal inhibitory concentration: > 50000 nM
Compound 4: no number, only a limit; the forecaster's own chance of this, stated with the estimate: 85%; the middle value lies beyond the limit too.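

Among these compounds, compound 3 and compound 4 both stand at a limit of the assay, not a number, and no step between them can be read. The compounds shown leave open whether 3-methylphenyl and 2-methylphenyl differ at all in this assay.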